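Triazole aryl variation on the spiro core: antiproliferative read-out

The source may report more compounds than this note shows. Statements on the series, on what has been measured and on what is new or still open speak of the compounds shown alone.

Measured compounds:
compound 1 `Cc1cccc(-n2nncc2CN2C(=O)C3(C(C#N)=C(N)Oc4c3c3nc5ccccc5nc3c3ccccc43)c3ccccc32)c1` — 39600 nM
compound 2 `N#CC1=C(N)Oc2c(c3nc4ccccc4nc3c3ccccc23)C12C(=O)N(Cc1cnnn1-c1ccccc1Br)c1ccccc12` — > 50000 nM
compound 3 `Cc1cc(C)cc(-n2nncc2CN2C(=O)C3(C(C#N)=C(N)Oc4c3c3nc5ccccc5nc3c3ccccc43)c3ccccc32)c1` — > 50000 nM

Going by the values given here, in a functional assay on A549 cells (Homo sapiens) for antiproliferative activity, read by MTT assay, with a stated time of 48 h (a lower number here means a stronger inhibitor, a higher number a weaker inhibitor), compound 1 gives 39600 nM and is the only member of the set with a number rather than a limit. Compound 2 sits at the limit of this assay, > 50000 nM, so no number is known for it. Compound 3 likewise sits at the limit, > 50000 nM. Both limits are the same one, (the limit of > 50000 nM in this assay, at which 2 of the 3 values shown sit).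

The unmeasured compound 4 `Cc1ccc(Cl)cc1-n1nncc1CN1C(=O)C2(C(C#N)=C(N)Oc3c2c2nc4ccccc4nc2c2ccccc32)c2ccccc21` differs from compound 1 only on the aryl group attached to the triazole nitrogen: 5-chloro-2-methylphenyl in place of 3-methylphenyl on an aromatic nitrogen.

Among the compounds with values here, two measured steps bear on this change, both starting from compound 1 and both moving the aryl group: an at least 1.2-fold higher number from compound 1 to compound 2 (0.10 log units; that floor lies within the scatter) and an at least 1.2-fold higher number from compound 1 to compound 3 (0.10 log units; that floor lies within the scatter). Each is a floor set by the limit and not a readable size, so the only thing they show is that neither a different substituent pattern nor an added methyl on the aryl ring gave a number below that of compound 1. The step that the two limits leave unreadable from compound 2 to compound 3 adds nothing readable.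

On that basis compound 4 is expected to land at or near the limit, a step of a 1.3-fold higher number from compound 1 to compound 4 (0.10 log units; within the scatter) toward weaker inhibition. The estimate for compound 4 is 50000 nM with a range of 25000 nM to 100000 nM.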

Compound 4, half-maximal inhibitory concentration: > 50000 nM
Compound 4 gave a limit, no number; the forecaster's own chance of this, stated with the estimate: 60%; the middle value lies on the limit itself.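

Placing 5-chloro-2-methylphenyl in place of 3-methylphenyl on the aromatic nitrogen gives an at least 1.2-fold higher number from compound 1 to compound 4 (0.10 log units; that floor lies within the scatter) in this assay, and this is a floor set by a limit, not a readable size. Going by these compounds alone, the change adds a chlorine to the aryl group and moves the methyl, yet it yields no number, so a chlorine-bearing aryl group at this position joins the 2-bromophenyl of compound 2 and the 3,5-dimethylphenyl of compound 3 at the limit, with compound 1 the only member that goes against this pattern. The steps among compounds 2, 3 and 4 cannot be read, so these three aryl groups cannot be ranked, and the series now stands as follows: the limit of > 50000 nM in this assay, at which 3 of the 4 values shown sit.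

With a number for compound 1 alone, the compounds shown do not tell how far any of the other aryl groups lies from it. From the compounds shown here alone, it remains open whether an amine or a carboxylic acid on the aryl ring, or a longer alkyl chain in place of that ring, would give a number rather than a limit on the shared core.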